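This account rests on a few compounds, and the source may have more. Where it says the series, first, only, none or still open, it means among the compounds named here.

The compounds share one core and differ in a single substituent. In a functional assay on A549 cells (Homo sapiens) for antiproliferative activity, read by MTT assay, with a stated time of 48 h (on this read-out higher numbers stand for weaker inhibition and lower numbers for stronger inhibition), compound 1 `CC(C)=CCC[C@]1(C)/C=C/[C@@H](OC(=O)C=C(C)C)[C@](C)(O)/C=C/C(=O)/C(CCl)=C\C1` gives 150 nM, compound 2 `CC[Si](CC)(CC)C/C1=C/C[C@](C)(CCC=C(C)C)/C=C/[C@@H](OC(=O)C=C(C)C)[C@](C)(O)/C=C/C1=O` gives 3100 nM and compound 3 `COCOC/C1=C/C[C@](C)(CCC=C(C)C)/C=C/[C@@H](OC(=O)C=C(C)C)[C@](C)(O)/C=C/C1=O` gives 2980 nM. Compound 3 thus belongs with the pair of higher numbers: the step of a 1.0-fold lower number from compound 2 to compound 3 (0.02 log units; within the scatter) lies within the scatter, and the step of a 20-fold higher number from compound 1 to compound 3 (1.30 log units; beyond the scatter) lies beyond it.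

Compound 4 `CCN(CC)C(=O)/C1=C/C[C@](C)(CCC=C(C)C)/C=C/[C@@H](OC(=O)C=C(C)C)[C@](C)(O)/C=C/C1=O` carries diethylcarbamoyl in place of (methoxymethoxy)methyl on a double-bonded ring carbon, (diethylcarbamoyl in place of (methoxymethoxy)methyl on a double-bonded ring carbon). For the measured compounds named here, three measured steps bear on this change. The large steps of a 21-fold higher number from compound 1 to compound 2 (1.32 log units; beyond the scatter) and a 20-fold higher number from compound 1 to compound 3 (1.30 log units; beyond the scatter) both start from the chlorine-bearing compound 1, and compound 4 has no chlorine to lose relative to compound 3. The closest guide is therefore the step of a 1.0-fold lower number from compound 2 to compound 3 (0.02 log units; within the scatter), in which one chlorine-free group replaced another and the number stayed within the scatter. Going by the values given here, no measured compound carries an amide, however, so this guide is loose and the range must stay wide.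

In this assay, the expected result is a 1.0-fold higher number from compound 3 to compound 4 (0.00 log units; within the scatter), which means no step beyond the scatter in either direction. The estimate for compound 4 is 3000 nM, with an expected range of 900 nM to 10000 nM.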

Compound 4, half-maximal inhibitory concentration: 11300 nM
Compound 4: the middle estimate sits 3.8-fold (0.58 log units) below what was measured; measured number outside the range, above it.
By their numbers in this assay, from the lowest: compound 1; then compounds 3 and 2 (each within the scatter of the next); then compound 4.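

In this assay, the position turns out not to be indifferent to the choice among chlorine-free groups: the earlier pair of such groups could not be told apart, whereas diethylcarbamoyl gives a 3.8-fold higher number from compound 3 to compound 4 (0.58 log units; beyond the scatter) and a 3.6-fold higher number from compound 2 to compound 4 (0.56 log units; beyond the scatter), both modest steps beyond the scatter. Against the chloromethyl group the change gives a 75-fold higher number from compound 1 to compound 4 (1.88 log units; beyond the scatter), and with all three of its steps beyond the scatter, compound 4 is the weakest of the four, which also shows that the number can climb further than the earlier compounds suggested. Nothing supplied here accounts for this result.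

The compounds shown leave open whether the higher number of compound 4 goes with the carbonyl standing on the double-bonded ring carbon, where the other three carry a saturated chain carbon, or with the diethylamino part of the group. They also leave open whether chlorine itself sets compound 1 apart, a question that a bromomethyl or hydroxymethyl group here would address, while a dimethylcarbamoyl group would test the size of the amide.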